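This account rests on a few compounds, and the source may have more. Where it says the series, first, only, none or still open, it means among the compounds named here.

Compound 2 `COc1cc(/C=C/C(=O)Nc2cc(C(=O)c3cc(OC)c(OC)c(OC)c3)ccc2OC)ccc1F` gives the highest of the two numbers in hand: in a functional assay on PC-3 cells (Homo sapiens) for cytotoxicity, read by MTT assay, with a stated time of 72 h (on this read-out lower numbers stand for stronger inhibition and higher numbers for weaker inhibition), compound 2 gives 14100 nM, and its nearest neighbour is compound 1 `C#CCOc1cccc(/C=C/C(=O)Nc2cc(C(=O)c3cc(OC)c(OC)c(OC)c3)ccc2OC)c1`, which in this assay gives 13100 nM. The move to compound 3 `COc1ccc(C(=O)c2cc(OC)c(OC)c(OC)c2)cc1NC(=O)/C=C/c1cccc(OC(F)(F)F)c1` is 3-(trifluoromethoxy)phenyl in place of 4-fluoro-3-methoxyphenyl on a double-bonded chain carbon bound to a double-bonded chain carbon. Within the data shown here, the one step that bears on it, an exchange of the aryl group at the same place, is a 1.1-fold higher number from compound 1 to compound 2 (0.03 log units; within the scatter). A step of no more than the scatter is therefore expected here, with no direction. For compound 3 the estimate in this assay is 13500 nM, range 5000 nM to 36000 nM, meaning an expected 1.0-fold lower number from compound 2 to compound 3 (0.02 log units; within the scatter).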

Compound 3, half-maximal inhibitory concentration: 7700 nM
Estimate against measurement, compound 3: 1.8-fold (0.24 log units) above, and the stated range covers the measured number.
By their numbers in this assay, from the lowest: compounds 3, 1 and 2 (each within the scatter of the next).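

In this assay, the 3-(trifluoromethoxy)phenyl group at this place stays within the scatter of both earlier aryl groups, with a 1.8-fold lower number from compound 2 to compound 3 (0.26 log units; within the scatter) and a 1.7-fold lower number from compound 1 to compound 3 (0.23 log units; within the scatter) as the two new steps. Three aryl groups on the double-bonded chain carbon, including the exchange of propargyl for trifluoromethyl on the oxygen, therefore still do not separate the compounds. No measurement shown accounts for these steps.

Open, as far as these compounds go, is whether an amine or a carboxylic acid in place of the trifluoromethoxy group would give a step beyond the scatter.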